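The source may report more compounds than this note shows. Statements on the series, on what has been measured and on what is new or still open speak of the compounds shown alone.

Compound 2 `Oc1ccc2cccc(NCC3=NCCN3)c2c1` stands alone among the numbers shown: in a functional assay for activation of Alpha-1D adrenergic receptor (Homo sapiens) (a higher number here means that more compound is needed for the effect, a lower number that less compound is needed), compound 2 gives 31.6 nM, the only actual value reported. Compound 1 `CCN(CC)C(=O)c1ccccc1OCc1c[nH]cn1` carries only a limit of the assay rather than a number. In this assay compound 1 gives < 100000 nM, which is the limit of < 100000 nM in this assay, at which 1 of the 2 values shown sits. Compound 3 `Oc1ccc2cccc(NCc3c[nH]cn3)c2c1` differs from compound 2 in one place: a group of 5 heavy atoms (3 carbon, 2 nitrogen; one five-membered aromatic ring with 2 hetero atoms) in place of a group of 5 heavy atoms (3 carbon, 2 nitrogen; one five-membered non-aromatic ring with 2 hetero atoms), on a saturated chain carbon bound to a nitrogen on an aromatic ring. Among the measured compounds shown here, no measured step of this kind exists here, so the size of the change is uncertain. The expectation is a step toward more compound being needed, beyond the usual scatter, a 32-fold higher number from compound 2 to compound 3 (1.50 log units; beyond the scatter). Compound 3 is therefore estimated at 1000 nM, with a range from 100 nM to 10000 nM.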

Compound 3, half-maximal effective concentration: < 5020 nM
Compound 3 gave a limit, no number (the forecaster's own chance of this, stated with the estimate: 15%); the middle value does not contradict the limit.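

In this assay compound 3 gives < 5020 nM, which is a limit and not a number. The step from compound 2 to compound 3 therefore cannot be read. The compounds shown leave open how much the 1H-imidazol-4-yl group changes the amount of compound needed.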